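The compounds below may be only part of what the source reports. "The series", "measured", "known", "first", "only" and "open" are said of these compounds alone.

Compound 3 `O=C(Nc1cccc(O)c1)c1cccc(N2C(=O)c3ccccc3C2=O)c1` is the starting point. For the measured compounds named here, in an in vitro functional assay on HEK293-A cells for antagonist activity at metabotropic glutamate receptor 5 (Rattus norvegicus), read by calcium flux (a lower number here means a stronger inhibitor, a higher number a weaker inhibitor), compound 3 gives 7790 nM, and this is the only actual number among the three values shown. Compound 1 `COc1ccccc1C(=O)Nc1cccc(NC(=O)c2ccc(Cl)c(Cl)c2)c1` returns a limit of this assay rather than a number: in this assay compound 1 gives > 30000 nM. Compound 2 `COc1ccccc1C(=O)Nc1cccc(NC(=O)C(C)C)c1` likewise stops at a limit: in this assay compound 2 gives > 30000 nM. Going by the values given here, the single step between measured compounds, a step that the two limits leave unreadable from compound 1 to compound 2, cannot be read because both of its ends sit at the limit of > 30000 nM in this assay, at which 2 of the 3 values shown sit.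

Compound 4 `O=C(Nc1cccc(Cl)c1)c1cccc(N2C(=O)c3ccccc3C2=O)c1` is the unmeasured partner of compound 3. The two differ by chloro in place of hydroxy on an aromatic carbon. Among the compounds with values here, no measured step concerns a change of this kind, and the step from compound 1 to compound 2 offers no readable size, so nothing among the measured pairs speaks for or against a shift in this assay. The expectation for compound 4 therefore rests on compound 3 alone, whose value of 7790 nM shows that the shared core of compound 3 and compound 4 does yield a measurable number. For compound 4 the estimated step is a 2.2-fold lower number from compound 3 to compound 4 (0.35 log units; beyond the scatter), a modest gain that could still fall within the scatter. Compound 4 is accordingly expected to give about 3500 nM in this assay, with a range from 900 nM to 15000 nM.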

Compound 4, half-maximal inhibitory concentration: 1780 nM
Estimate against measurement, compound 4: 2.0-fold (0.29 log units) above; the range from low to high includes it.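

Replacing hydroxy with chloro on this aromatic carbon, meta to a large group, gives a 4.4-fold lower number from compound 3 to compound 4 (0.64 log units; beyond the scatter) in this assay, the first step of readable size among the compounds shown, as the earlier step between the two limits could not be read. It also shows that the hydroxy is not needed for a measurable value at this position on the shared core: the hydrogen-bond donor and acceptor counted for hydroxy are gone in chloro, and the number is lower, not higher. Nothing measured here accounts for the size of this shift.

Going by these compounds, whether the gain belongs to chloro itself or simply to the loss of hydroxy remains open, and so does what a methyl, an amine or a carboxylic acid in the same place would give. Also open, on these data alone, is whether the exchange of hydroxy for chloro would give a step of similar size on a different core, or whether it holds only for the core shared by compound 3 and compound 4.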